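Notes on the amide variant of compound 2

The source may hold more compounds than are shown below. What is called first, only, known or untested is meant among the compounds shown, and "the series" means these compounds.

Measured so far in a functional assay on HOP-92 cells (Homo sapiens) for inhibition, read by sulforhodamine B assay, with a stated time of 48 h; on this read-out lower numbers stand for higher toxicity in this test and higher numbers for lower toxicity in this test:
- compound 1, `COc1cc(-c2nn(-c3cccc(NC(=O)Nc4cc(C(F)(F)F)cc(C(F)(F)F)c4)c3)cc2-c2ccncc2)ccc1Cl`: 4720 nM
- compound 2, `COc1cc(-c2nn(-c3cccc(NC(=O)Nc4ccc(Cl)c(Cl)c4)c3)cc2-c2ccncc2)ccc1Cl`: a limit of the assay, > 50000 nM
- compound 3, `O=C(Nc1cccc(-n2cc(-c3ccncc3)c(-c3ccc(Cl)c(O)c3)n2)c1)Nc1ccc(Cl)c(Cl)c1`: a limit of the assay, > 32500 nM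

Compound 2 stands at the limit of the limit of > 50000 nM in this assay, at which 1 of the 3 values shown sits, so no number is known for it. Compound 3 sits at the limit of the limit of > 32500 nM in this assay, at which 1 of the 3 values shown sits, and the step that the two limits leave unreadable from compound 2 to compound 3 therefore cannot be sized. For the measured compounds named here, compound 1 is the only compound of the three with a number in this assay.

Compound 4, `COc1cc(-c2nn(-c3cccc(NC(=O)c4ccc(Cl)c(C(F)(F)F)c4)c3)cc2-c2ccncc2)ccc1Cl`, differs from compound 2 by 4-chloro-3-(trifluoromethyl)phenyl in place of (3,4-dichlorophenyl)amino on a carbonyl carbon; the urea becomes an amide. Going by the values given here, no measured step covers a change of this kind, and the one measured step in the set is unreadable, so nothing read from the data sets the direction or size for this assay. Compound 2 stands at a limit, and compound 1 shows that a number can be reached in this series.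

Compound 4 is expected to give about 20000 nM, within 5000 nM to 50000 nM. The step of an at least 2.5-fold lower number from compound 2 to compound 4 (0.39 log units; beyond the scatter) is thus an estimate only, carrying the chance that a limit is reported again.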

Compound 4, concentration lethal to 50% of the cells: > 32500 nM
Compound 4: no number, only a limit; the forecaster's own chance of this, stated with the estimate: 40%; middle value at least 1.6-fold (0.21 log units) away from the limit.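

In this assay compound 4 gives > 32500 nM, a limit of the assay and not a number. For the compounds shown here, compound 2 also stands at a limit, so no step between compound 2 and compound 4 can be read. On these data alone, whether the amide compound 4 and the urea compound 2 differ at all in this assay stays open.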